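The compounds below may be only part of what the source reports. "The series", "measured", "known", "first", "only" and "open" are said of these compounds alone.

Series notes. The shared core is a diaryl ketone carrying a trimethoxyphenyl unit, seen in compound 2 `COc1ccc(C(=O)c2cc(OC)c(OC)c(OC)c2)c(OC)c1O`, compound 3 `COc1cc(C(=O)c2ccc3c(c2)oc(=O)n3S(C)(=O)=O)cc(OC)c1OC` and compound 1 `COc1ccc(C(=O)c2ccc(OC)c(O)c2OC)cc1`. Growth inhibition was measured in a functional assay on A498 cells (Homo sapiens) for cytotoxicity, read by sulforhodamine B assay, with a stated time of 48 h; a higher number here means a weaker inhibitor of growth, a lower number a stronger inhibitor of growth. In this assay compound 1 gives "not determined" (no result reported). In this assay compound 2 gives 2720 nM. In this assay compound 3 gives 3110 nM. On these two numbers compound 2 has the lower one, but its gap to compound 3 lies within the scatter, so the two cannot be ordered.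

Compound 4 `COc1ccc(C(=O)c2cc(OC)c(OC)c(OC)c2)c(OC)c1N` is the unmeasured partner of compound 2. The change is amino in place of hydroxy on an aromatic carbon. Going by the values given here, no pair of measured compounds shows this exchange, so the step from compound 2 to compound 4 has to be guessed from the change alone.

The expectation for compound 4 in this assay is that the change moves the number little, with a step of a 1.4-fold lower number from compound 2 to compound 4 (0.13 log units; within the scatter), in either direction not clearly beyond the scatter. For compound 4 the estimated value in this assay is 2000 nM, with a range from 600 nM to 7000 nM.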

Compound 4, concentration for 50% growth inhibition: 22.1 nM
The estimate for compound 4 lay 90-fold (1.96 log units) above the measured number, outside the stated range (below it).
By their numbers in this assay, from the lowest: compound 4; then compounds 2 and 3 (each within the scatter of the next).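

In this assay, amino in place of hydroxy on an aromatic carbon, ortho to two methoxy groups, gives a 120-fold lower number from compound 2 to compound 4 (2.09 log units; beyond the scatter). This position therefore responds strongly to the exchange of a single heavy atom, although the hydrogen-bond donor and acceptor counts of the two groups are the same. The earlier compounds offered no step at this position, and no measurement at hand accounts for the size of this one.

From the compounds shown here alone, whether a methylamino group, an acetamide or a fluorine atom at this position would also keep the number low remains open. Going by these compounds, the exchange is read only once, on the core of compound 2, so it is also open whether the same step would appear on another core.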